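Furan-2-yl for 3-chlorophenyl on a Shared Pyrazolopyrimidinone Core

The compounds below may be only part of what the source reports. "The series", "measured", "known", "first", "only" and "open" are said of these compounds alone.

Measured so far:
compound 1 `O=C(Nn1c(-c2cccc([N+](=O)[O-])c2)nc2c(-c3cccc(Cl)c3)n[nH]c2c1=O)c1ccccc1` — 93.8%
compound 2 `COc1cccc(-c2nc3c(-c4cccc(Cl)c4)n[nH]c3c(=O)n2NC(=O)c2ccccc2)c1` — 93.5%

In a functional assay on DU-145 cells (Homo sapiens) for cytotoxicity, read by sulforhodamine B assay, with a stated time of 2 days, tested at 100 uM (a higher number here means more inhibition at the concentration tested (going by the name of the read-out), a lower number less inhibition), compound 1 gives 93.8%, the highest of the two numbers shown, with compound 2 as its nearest neighbour at 93.5%; the step of a number 0.3 percentage points lower from compound 1 to compound 2 (within the scatter) lies within the scatter, so the two cannot be ordered. That step exchanges a nitro for a methoxy on an aromatic carbon and leaves the read-out essentially unchanged.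

Compound 3 `O=C(Nn1c(-c2cccc([N+](=O)[O-])c2)nc2c(-c3ccco3)n[nH]c2c1=O)c1ccccc1` has not been measured in this assay. It differs from compound 1 at another place: furan-2-yl in place of 3-chlorophenyl on an aromatic carbon. For the measured compounds named here, no measured step touches this place, so the only guide is that both compounds measured so far sit near the top of the scale in this assay at the tested concentration.

Going by the values given here, compound 3 is therefore expected to remain strongly inhibiting, with a step of a number 8.8 percentage points lower from compound 1 to compound 3 (within the scatter) that allows for some loss, since the one measured step, a number 0.3 percentage points lower from compound 1 to compound 2 (within the scatter), says nothing about this part of the core. The estimate for compound 3 is 85%, with a range from 60% to 98%.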

Compound 3, a percentage reported as inhibition, at one concentration (the size of the read-out at that concentration, not a potency): 16.1%
Estimate against measurement, compound 3: 68.9 percentage points above; measured number below the stated range.
By their numbers in this assay, from the lowest: compound 3; then compounds 2 and 1 (each within the scatter of the next).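

In this assay, furan-2-yl in place of 3-chlorophenyl gives a number 77.7 percentage points lower from compound 1 to compound 3 (beyond the scatter), so the group on this aromatic carbon of the five-membered ring can decide whether the read-out stays near the top of the scale. The earlier pair gave no hint of this, as its change of nitro to methoxy elsewhere on the molecule produced only a number 0.3 percentage points lower from compound 1 to compound 2 (within the scatter); with the nitro group held constant, the read-out proves far more sensitive to the exchange at this position. No accompanying measurement speaks to what lies behind the drop.

Furan-2-yl differs from 3-chlorophenyl in ring size, in its ring oxygen and in the absence of chlorine, and this single pair cannot separate those differences, nor show whether the same loss would occur with methoxy in place of nitro. A plain phenyl, a 3-methylphenyl or a thiophen-2-yl at this position would help show which of them goes with the high read-out, and whether the furan-2-yl result reflects the loss of the chlorine or the change of ring.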